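Side-chain swap on the shared core: working notes

The source may report more compounds than this note shows. Statements on the series, on what has been measured and on what is new or still open speak of the compounds shown alone.

Measured in a physicochemical assay for solubility, at pH 6.8; on this read-out lower numbers stand for lower solubility and higher numbers for higher solubility:
- compound 1 `NCc1ccc(-n2cc(-c3ccc4cc[nH]c4c3)c(C(F)(F)F)n2)cc1`: 62000 nM
- compound 2 `NCCCCn1cc(-c2ccc3cc[nH]c3c2)c(C(F)(F)F)n1`: 73000 nM

Only these two compounds have been measured so far. Compound 2, at 73000 nM, lies within the scatter of compound 1, at 62000 nM.

The next structure is compound 3 `N[C@@H]1CC[C@@H](n2cc(-c3ccc4cc[nH]c4c3)c(C(F)(F)F)n2)C1`, and the change from compound 2 is a group of 6 heavy atoms (5 carbon, 1 nitrogen; one five-membered non-aromatic ring of carbon only) in place of a group of 5 heavy atoms (4 carbon, 1 nitrogen; no ring), on an aromatic nitrogen. Among the measured compounds shown here, one measured step bears on it, made on the same aromatic nitrogen: a 1.2-fold higher number from compound 1 to compound 2 (0.07 log units; within the scatter). That step stayed within the scatter. For the measured compounds named here, no measured compound carries a five-membered non-aromatic ring of carbon only at this place, so the evidence is thin. No step beyond the scatter is expected in this assay, and no direction is favoured. The estimated step is a 1.0-fold lower number from compound 2 to compound 3 (0.02 log units; within the scatter). For compound 3 the expected value is 70000 nM, with an estimated range of 35000 nM to 140000 nM.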

Compound 3, solubility: 587000 nM
Beside the measured number, compound 3's estimate is 8.4-fold (0.92 log units) below it; measured number above the stated range.
By their numbers in this assay, from the lowest: compounds 1 and 2 (each within the scatter of the next); then compound 3.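

In this assay the group on this aromatic nitrogen can move the number beyond the scatter: the five-membered non-aromatic ring of carbon only gives an 8.0-fold higher number from compound 2 to compound 3 (0.91 log units; beyond the scatter) and also a 9.5-fold higher number from compound 1 to compound 3 (0.98 log units; beyond the scatter) when set against the two earlier groups. The earlier swap gave no such sign, with a 1.2-fold higher number from compound 1 to compound 2 (0.07 log units; within the scatter) staying within the scatter. No measurement in hand accounts for the size of this step.

The compounds shown do not separate the contribution of the ring from that of its 2 defined stereocentres or of the placing of the amine on it. The other stereoisomers of compound 3, the same ring without the amine, a six-membered non-aromatic ring of carbon only, or a carboxylic acid in place of the amine would each bear on that question.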